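The source may hold more compounds than are shown below. What is called first, only, known or untested is meant among the compounds shown, and "the series" means these compounds.

Measured in an ADME assay on microsomes from liver (Mus musculus) for metabolic stability, tested at 5 uM; on this read-out higher numbers stand for a longer-lived compound and lower numbers for a shorter-lived compound:
- Compound 1 `CNS(=O)(=O)c1cc(C(=O)O)ccc1NCCCCCCCC(F)(F)F`: > 1 h
- Compound 2 `O=C(O)c1ccc(NCCCCCCCC(F)(F)F)c(S(=O)(=O)N2CCOCC2)c1`: > 1 h
- Compound 3 `O=C(O)c1ccc(NCCCCCCCC(F)(F)F)c(S(=O)(=O)NC2CCCC2)c1`: > 1 h

Compound 3 stands at > 1 h, which is a limit and not a number. The other two entries are limits as well, so the series offers (the limit of > 1 h in this assay, at which 3 of the 3 values shown sit).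

Compound 4 `O=C(O)c1ccc(NCCCCCCCC(F)(F)F)c(S(=O)(=O)NC2CCOCC2)c1` carries oxan-4-yl in place of cyclopentyl on a sulfonamide nitrogen.

Among the compounds with values here, three measured steps bear on this change: a step that the two limits leave unreadable from compound 1 to compound 3, a step that the two limits leave unreadable from compound 1 to compound 2 and a step that the two limits leave unreadable from compound 2 to compound 3. None of them has a readable size, so they give no direction for this assay. They show only that methylamino, morpholin-4-yl and cyclopentylamino on the sulfonyl sulfur all reached the same limit. On that basis, no step beyond the scatter is expected, and another limit is the most likely report.

The expected step is a step that the limit leaves unreadable from compound 3 to compound 4. For compound 4 the estimate is 2 h, with an expected range from 1 h to 4 h.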

Compound 4, half-life in the Mus musculus assay: > 1 h
Compound 4: a limit, no number; the forecaster's own chance of this, stated with the estimate: 85%; the middle value does not contradict the limit.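

In the Mus musculus assay compound 4 gives > 1 h, a limit and not a number. No step from compound 1, compound 2 or compound 3 to compound 4 can be read, and the series stays at one limit: the limit of > 1 h in the Mus musculus assay, at which 4 of the 4 values shown sit.

The compounds shown leave open whether the groups on the sulfonyl sulfur differ at all in half-life.

In a physicochemical assay for solubility, in phosphate buffer, measured as kinetic solubility, at pH 7.4, tested at 250 uM (on this read-out higher numbers stand for higher solubility and lower numbers for lower solubility), compound 3 gives 223000 nM and compound 4 gives 244000 nM. In the physicochemical assay the two values are separated by a 1.1-fold higher number from compound 3 to compound 4 (0.04 log units; within the scatter).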